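Sulfur for oxygen on a carbamoyl-bearing nitrogen

The source may hold more compounds than are shown below. What is called first, only, known or untested is meant among the compounds shown, and "the series" means these compounds.

Measured in an ADME assay on MT4 cells (Homo sapiens) for cytotoxicity, read by MTT assay, with a stated time of 96 h (a higher number here means that more compound is tolerated, a lower number that less compound is tolerated), so far
Compound 1 `C/C(=N\O)c1ccc2[nH]c(-c3ccc(Cl)cc3)nc2c1` gives 20000 nM
Compound 2 `C/C(=N\NC(N)=O)c1ccc2[nH]c(-c3ccc(Cl)cc3)nc2c1` is recorded as "not determined" (no result reported)
Compound 3 `COc1ccc(-c2nc3cc(/C(C)=N/NC(N)=O)ccc3[nH]2)cc1` is recorded as "not determined" (no result reported)

Compound 2 has no place on the numbers at all, since no result was reported for it, and compound 3 is the one further entry without a number. For the measured compounds named here, the only number in this assay belongs to compound 1, which gives 20000 nM and serves as the sole reference point for this series.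

Compound 4 `C/C(=N\NC(N)=S)c1ccc2[nH]c(-c3ccc(Cl)cc3)nc2c1` is still to be measured. The change is a group of 3 heavy atoms (1 carbon, 1 nitrogen, 1 sulfur; no ring) in place of a group of 3 heavy atoms (1 carbon, 1 nitrogen, 1 oxygen; no ring), on an amine nitrogen and in it the carbamoyl leaves and a group with sulfur in place of oxygen enters, on an amine nitrogen whose other neighbour is a double-bonded nitrogen. Going by the values given here, no measured step between these compounds exists to size this change, so no step beyond the scatter is expected in this assay, and that expectation is weakly grounded. Taking compound 1 at 20000 nM as the guide, the expected value for compound 4 is 15000 nM (estimated range 4000 nM to 60000 nM).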

Compound 4, half-maximal cytotoxic concentration: 2000 nM
Estimate against measurement, compound 4: 7.5-fold (0.88 log units) above; the measured number lies below the stated range.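

In this assay, the sulfur-bearing group on the double-bonded nitrogen, in place of one oxygen atom, gives a 10-fold lower number from compound 1 to compound 4 (1.00 log units; beyond the scatter), the first sign that what stands at this place can move the number beyond the scatter. The exchange of sulfur for oxygen on the amine nitrogen cannot itself be read, since compound 2 has no number to set against compound 4, so the step cannot be assigned to the sulfur rather than to the larger group as a whole. Nothing measured here accounts for the step.

The compounds shown leave open how an amine or an acetyl group on the double-bonded nitrogen would stand in this assay. They also leave open whether the sulfur-bearing group would give a similar number on the core of compound 3.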